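Series notes: removing the methoxy group from compound 1

A few compounds are considered here, and "the series" means these few. Any claim that something is new, unique, unknown or untested is made for them only; others in the source may bear on it.

Of the compounds shown here, two have numbers so far in an ADME assay on NIH3T3 cells (Mus musculus) for cytotoxicity, read by XTT assay, with a stated time of 24 h; on this read-out lower numbers stand for stronger inhibition and higher numbers for weaker inhibition. Compound 1 `COc1ccc(-c2csc(N3N=C(c4ccc(C)s4)CC3c3ccc(F)cc3)n2)cc1` gives 147 ug/mL, and compound 2 `COc1ccc(-c2csc(N3N=C(c4ccc(Cl)s4)CC3c3ccc(F)cc3)n2)cc1` gives 103 ug/mL. Compound 1 stands highest of the two, with compound 2 nearest, and the step of a 1.4-fold lower number from compound 1 to compound 2 (0.15 log units; within the scatter) lies within the scatter, so the two compounds cannot be told apart on this read-out.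

Compound 3 `Cc1ccc(C2=NN(c3nc(-c4ccccc4)cs3)C(c3ccc(F)cc3)C2)s1` is not yet measured. It differs from compound 1 in one place: hydrogen in place of methoxy on an aromatic carbon. Among the compounds with values here, no measured step touches this change. Within the data shown here, the only step in hand, a 1.4-fold lower number from compound 1 to compound 2 (0.15 log units; within the scatter), concerns a chloro in place of methyl on an aromatic carbon and was itself within the scatter. Among the measured compounds shown here, nothing measured therefore bears on the loss of the methoxy, and the one step seen in the set was small. The expectation is no step beyond the scatter in this assay, in either direction, with wide uncertainty. Compound 3 is estimated at 140 ug/mL, between 65 ug/mL and 300 ug/mL. For the measured compounds named here, the expected step of a 1.1-fold lower number from compound 1 to compound 3 (0.02 log units; within the scatter) is thus a flat one, resting on no precedent.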

Compound 3, half-maximal inhibitory concentration: > 500 ug/mL
Compound 3: a limit, no number; the forecaster's own chance of this, stated with the estimate: 10%; middle value at least 3.5-fold (0.55 log units) away from the limit.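

Within the data shown here, the methoxy place is the first to show a step beyond the scatter. In this assay, the change from 4-methoxyphenyl to phenyl gives an at least 3.4-fold higher number from compound 1 to compound 3 (0.53 log units; beyond the scatter), whereas the chloro in place of methyl, made at a different place, gave only a 1.4-fold lower number from compound 1 to compound 2 (0.15 log units; within the scatter). The direction is towards weaker inhibition on losing the methoxy, and the size of the step is only a lower bound, since the reading for compound 3 is a limit and not a number: the limit of > 500 ug/mL in this assay, at which 1 of the 3 values shown sits.

Only methoxy and hydrogen have been compared at this place, so the data cannot say whether the oxygen, the methyl carbon or the group as a whole carries the difference, and they give no cause for the step. From the compounds shown here alone, it also remains open whether a hydroxy group, a fluoro group or a longer chain such as ethoxy, set on the same aromatic carbon, would stay with compound 1 or go with compound 3, and whether the same change would give a similar step in the chloro-bearing compound 2.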